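This account rests on a few compounds, and the source may have more. Where it says the series, first, only, none or still open, it means among the compounds named here.

In an ADME assay on a cell-free system (plasma, Homo sapiens) for protein binding, compound 1 (`NS(=O)(=O)c1ccc(-c2nc(NCc3ccccn3)c3c(-c4ccccc4)cccc3n2)cn1`) gives > 99.5%, which is a limit of the assay and not a number. Compound 2 (`NC(=O)c1cncc(-c2nc(NCc3ccccn3)c3c(-c4ccccc4)cccc3n2)c1`) gives > 99.5%, which is also a limit, so its position is known only as a limit. Compound 3 (`CS(=O)(=O)Nc1cncc(-c2nc(NCc3ccccn3)c3c(-c4ccccc4)cccc3n2)c1`) differs from it by one change, (methanesulfonamido in place of carbamoyl on an aromatic carbon), with methanesulfonamido in place of carbamoyl on an aromatic carbon. Among the compounds with values here, the one measured step that bears on this change, a step that the two limits leave unreadable from compound 1 to compound 2, offers no size to carry over. All that the measured pair shows in this assay is the limit of > 99.5% in this assay, at which 2 of the 2 values shown sit. The expected change is an at least 1.2-fold higher unbound fraction from compound 2 to compound 3 (0.07 log units; that floor lies within the scatter), and no shift beyond the scatter can be predicted in either direction. For compound 3 the estimated plasma protein binding is 99.4%, with an expected range from 98% to 99.9%.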

Compound 3, plasma protein binding: > 99.5%
Compound 3 was reported as a limit; the forecaster's own chance of this, stated with the estimate: 55%; middle value at least 1.2-fold (0.07 log units) (unbound fraction) away from the limit.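

In this assay, within the data shown here, compound 1, compound 2 and compound 3 all sit at a limit of the assay and not at a number, so no step among them can be read. The compounds shown leave open how much of each is unbound, and whether methanesulfonamido in place of carbamoyl changes that.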